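The source may hold more compounds than are shown below. What is called first, only, known or untested is meant among the compounds shown, and "the series" means these compounds.

Measured so far in a functional assay (Oryctolagus cuniculus) for inhibition of platelet-activating factor receptor (Cavia porcellus); a lower number here means a stronger inhibitor, a higher number a weaker inhibitor:
- compound 1 `CCCCCCCC(=O)OCC1CN(C(=O)c2cc(OC)c(OC)c(OC)c2)CCN1C(=O)c1cc(OC)c(OC)c(OC)c1`: compound 1 gives 310 nM
- compound 2 `CCC(CC)C(=O)OCC1CN(C(=O)c2cc(OC)c(OC)c(OC)c2)CCN1C(=O)c1cc(OC)c(OC)c(OC)c1`: compound 2 gives 70 nM; 40 nM; 60 nM (3 entries)

Compound 1 is the weaker of the two shown; compound 2 lies well below it, and the three entries for compound 2 the several entries of compound 2 in this assay, 70 nM; 40 nM; 60 nM (3 entries) agree with each other within the usual scatter. Among the compounds with values here, no pair differing in a single place has been measured, so no step size is known directly.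

Compound 3 `CCC(C)CNC(=O)OCC1CN(C(=O)c2cc(OC)c(OC)c(OC)c2)CCN1C(=O)c1cc(OC)c(OC)c(OC)c1` has not been measured in this assay. It differs from compound 1 as follows: (2-methylbutyl)amino in place of heptyl on a carbonyl carbon. The change replaces the ester of compound 1 with a carbamate and shortens the chain; the shorter, branched chain of compound 2 is the only hint in the shown numbers. A moderate improvement on compound 1 is expected, a 2.6-fold lower number from compound 1 to compound 3 (0.41 log units; beyond the scatter), of uncertain size. Compound 3 is estimated at 120 nM, with a range from 40 nM to 400 nM.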

Compound 3, half-maximal inhibitory concentration: 470 nM
The estimate for compound 3 lay 3.9-fold (0.59 log units) below the measured number, outside the stated range (above it).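

In this assay, (2-methylbutyl)amino in place of heptyl on a carbonyl carbon gives a 1.5-fold higher number from compound 1 to compound 3 (0.18 log units; within the scatter). At this position, then, the ester of compound 1 and the carbamate of compound 3 cannot be told apart by this read-out, even though the new group brings a nitrogen and a hydrogen-bond donor and the chain is also different. Nothing in the data shown gives a cause for this result.

From the compounds shown here alone, the link and the chain change together in this one step, so it remains open whether each has no effect of its own or whether their effects cancel. A heptylamino group on the same carbonyl carbon would keep the chain of compound 1 and change only the link, separating the two contributions.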